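The compounds below may be only part of what the source reports. "The series", "measured", "known", "first", "only" and "open" are said of these compounds alone.

Working notes on the chalcone-benzoxaborole series.

Compound 1 `COc1ccccc1C(=O)/C=C/c1ccc2c(c1)B(O)OC2` and compound 2 `COc1cccc(C(=O)/C=C/c2ccc3c(c2)B(O)OC3)c1` share the same atoms joined differently; the difference between the two cores is not broken down here. In a toxicity assay on MCF-10A cells (Homo sapiens) for cytotoxicity, read by MTT assay, with a stated time of 48 h (a higher number here means a weaker inhibitor, a lower number a stronger inhibitor), compound 1 gives 9100 nM, and compound 2 gives 7400 nM; the two numbers lie within the scatter of each other, so no ordering is drawn.

Compound 3 `COCOc1ccccc1C(=O)/C=C/c1ccc2c(c1)B(O)OC2` is compound 1 carrying the change (methoxy in place of hydrogen on a saturated chain carbon bound to an oxygen on an aromatic ring). In this assay compound 3 gives 11700 nM, and the step of a 1.3-fold higher number from compound 1 to compound 3 (0.11 log units; within the scatter) is small, within the scatter.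

Compound 4 `COCOc1cccc(C(=O)/C=C/c2ccc3c(c2)B(O)OC3)c1` is compound 2 carrying the change (methoxy in place of hydrogen on a saturated chain carbon bound to an oxygen on an aromatic ring), the same change seen once before, from compound 1 to compound 3. Among the measured compounds shown here, with only that one precedent, the expectation rests on its size: a step of a 1.3-fold higher number from compound 2 to compound 4 (0.11 log units; within the scatter) is expected, of about the magnitude of the earlier one, because a 1.3-fold higher number from compound 1 to compound 3 (0.11 log units; within the scatter) stayed within the scatter.

For compound 4 in this assay the estimate is 9500 nM, with a likely range from 5000 nM to 18000 nM.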

Compound 4, half-maximal inhibitory concentration: 48100 nM
For compound 4 the middle estimate is 5.1-fold (0.70 log units) below the measured one; the measured number lies above the stated range.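

In this assay the new step is a 6.5-fold higher number from compound 2 to compound 4 (0.81 log units; beyond the scatter), so methoxy in place of hydrogen on a saturated chain carbon bound to an oxygen on an aromatic ring does not carry from one core to the other at a fixed size: the same change on two cores in this assay, a 1.3-fold higher number (0.11 log units; within the scatter) from compound 1 to compound 3 and a 6.5-fold higher number (0.81 log units; beyond the scatter) from compound 2 to compound 4, 5.1-fold (0.70 log units) apart, beyond the scatter of two such steps

For these two cores, the size of the step on the core of compound 1 is therefore no reliable guide to its size on the core of compound 2. Among the compounds shown here, two pairs show only that the step differs between these cores; they do not show why it differs, and they give no rule for any further core.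

As far as these compounds go, it remains open whether a longer chain such as ethoxymethoxy, or an amine or a carboxylic acid in place of methoxymethoxy, would follow the small step or the large one. Also open, from the compounds shown here alone, is whether the same gap between the two steps would appear in any read-out other than this assay.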